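The source may report more compounds than this note shows. Statements on the series, on what has been measured and on what is new or still open speak of the compounds shown alone.

Measured in a physicochemical assay for solubility; on this read-out lower numbers stand for lower solubility and higher numbers for higher solubility:
compound 1 `O=S(=O)(Nc1ccncn1)c1ccc2c(c1)OCC[C@@H]2c1ccc(C(F)(F)F)cc1-c1ccc(F)cn1` gives 181000 nM
compound 2 `O=S(=O)(Nc1nccs1)c1ccc2c(c1)OCC[C@H]2c1ccc(C(F)(F)F)cc1-n1ccnn1` gives 154000 nM
compound 3 `O=C1OCCN1c1cc(C(F)(F)F)ccc1[C@H]1CCOc2cc(S(=O)(=O)Nc3nccs3)ccc21` gives 295000 nM

Compound 3 has the highest of the three numbers, yet its gaps to compound 1 and to compound 2 both lie within the scatter, so no order among the three can be read from this assay. Compound 4 `O=S(=O)(Nc1nccs1)c1ccc2c(c1)OCC[C@@H]2c1ccc(C(F)(F)F)cc1-c1ccc(F)cc1` is not yet measured. It differs from compound 3 in one place: 4-fluorophenyl in place of 2-oxo-1,3-oxazolidin-3-yl on an aromatic carbon. Among the measured compounds shown here, the 2-oxo-1,3-oxazolidin-3-yl is the only group among the four with hydrogen-bond acceptors at that position. For this assay a modest step downward is expected, a 2.7-fold lower number from compound 3 to compound 4 (0.43 log units; beyond the scatter), likely close to the edge of the scatter. Compound 4 is thus expected to give about 110000 nM, within 45000 nM to 260000 nM.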

Compound 4, solubility: 39000 nM
For compound 4 the middle estimate is 2.8-fold (0.45 log units) above the measured one; the whole stated range lies above it.
By their numbers in this assay, from the lowest: compound 4; then compounds 2, 1 and 3 (each within the scatter of the next).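

Working from this assay, the aromatic carbon meta to a trifluoromethyl group is now shown to matter: 4-fluorophenyl in place of 2-oxo-1,3-oxazolidin-3-yl gives a 7.6-fold lower number from compound 3 to compound 4 (0.88 log units; beyond the scatter) and so the first step in the series beyond the scatter. The change swaps a group with hydrogen-bond acceptors for one without, but no supporting measurement explains the drop. Open, on these data alone, is whether the acceptors themselves track with this read-out, and how an amine or a carboxylic acid at this position would read.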